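Swapping isopropyl for 4-methoxyphenyl on a weak compound

This account rests on a few compounds, and the source may have more. Where it says the series, first, only, none or still open, it means among the compounds named here.

Measured in a functional assay on A549 cells (Homo sapiens) for antiproliferative activity, read by MTT assay, with a stated time of 72 h (a lower number here means a stronger inhibitor, a higher number a weaker inhibitor), as follows
Compound 1 `O=C1COc2ccc(-c3cnc(Cl)c(NS(=O)(=O)c4ccc(F)cc4)c3)cc2N1` gives > 40000 nM as a limit
Compound 2 `CC(C)N1C(=O)COc2ccc(-c3cccc(NS(=O)(=O)c4ccc(F)cc4)c3)cc21` gives 29400 nM as a number
Compound 3 `COc1ccc(N2C(=O)COc3ccc(-c4cnc5ccccc5c4)cc32)cc1` gives > 40000 nM as a limit

Compound 2 alone has a true number, while compound 1 and compound 3 report only limits. Compound 4 `COc1ccc(N2C(=O)COc3ccc(-c4cccc(NS(=O)(=O)c5ccc(F)cc5)c4)cc32)cc1` differs from compound 2 in one place 4-methoxyphenyl in place of isopropyl on an amide-type nitrogen in a ring and carries 4-methoxyphenyl in place of isopropyl on an amide-type nitrogen in a ring. Compound 3 carries the same 4-methoxyphenyl, and its value is only a limit. Within the data shown here, no measured pair shows this swap, so no change beyond the scatter is expected in this assay in either direction. The estimate is a 1.1-fold lower number from compound 2 to compound 4 (0.02 log units; within the scatter) and stays an expectation. For compound 4 the estimated value is 28000 nM with an expected range from 10000 nM to 70000 nM in this estimate.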

Compound 4, half-maximal inhibitory concentration: 38200 nM
The estimate for compound 4 lay 1.4-fold (0.13 log units) below the measured number; the measured number falls inside the stated range.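

With 4-methoxyphenyl in place of isopropyl on the amide-type nitrogen in a ring, this assay shows a 1.3-fold higher number from compound 2 to compound 4 (0.11 log units; within the scatter). This first direct comparison at this position shows that the larger group, which brings an aromatic ring, leaves the result within the scatter, and neither compound is a strong inhibitor. Both numbers also lie close to the highest value this read-out reports, leaving little room to see any further weakening: the limit of > 40000 nM in this assay, at which 2 of the 4 values shown sit.

On these data alone, whether an amine or a carboxylic acid on a longer chain at this nitrogen would give a stronger inhibitor remains open.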